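From a phenethyl chain to 4-chlorophenyl on sulfur

A few compounds are considered here, and "the series" means these few. Any claim that something is new, unique, unknown or untested is made for them only; others in the source may bear on it.

Three measured compounds share one core and differ in the group carried on a sulfur. In a functional assay on A549 cells (Homo sapiens) for inhibition, read by CCK-8 assay, with a stated time of 72 h, tested at 8 uM (a higher number here means more inhibition of growth at the concentration tested, a lower number less inhibition of growth), compound 1 `COc1ccc(SCc2ccc(C(=O)Nc3ccccc3N)cc2)cc1` gives 70.7%, compound 2 `CC(C)(C)c1ccc(SCc2ccc(C(=O)Nc3ccccc3N)cc2)cc1` gives 67% and compound 3 `Nc1ccccc1NC(=O)c1ccc(CSCCc2ccccc2)cc1` gives 84.1%. Compound 3 therefore stands highest of the three, beyond the scatter from both of the others.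

The next compound is compound 4 `Nc1ccccc1NC(=O)c1ccc(CSc2ccc(Cl)cc2)cc1`. Its difference from compound 3 is 4-chlorophenyl in place of phenethyl on a sulfur. Compound 4 thus carries a substituted phenyl group on the sulfur, as compound 1 and compound 2 do.

Within the data shown here, two measured steps bear on this change. The closer one runs the opposite way, with phenethyl replacing 4-methoxyphenyl: a number 13.4 percentage points higher from compound 1 to compound 3 (beyond the scatter). The other swaps one group on the aromatic ring for another: a number 3.7 percentage points lower from compound 1 to compound 2 (within the scatter). Among the measured compounds shown here, that pair suggests that the choice of ring group may matter little, although no chlorinated compound has been measured yet. In this assay, a fall of similar size to the first step is therefore expected, and the estimated step is a number 14.1 percentage points lower from compound 3 to compound 4 (beyond the scatter). For compound 4 the expected value is 70%, with an estimated range from 58% to 82%.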

Compound 4, percent growth inhibition at one concentration: 50.4%
The estimate for compound 4 lay 19.6 percentage points above the measured number; the whole stated range lies above it.
By their numbers in this assay, from the lowest: compound 4; then compounds 2 and 1 (each within the scatter of the next); then compound 3.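

In this assay, the group on the phenyl ring now matters: chloro in place of tert-butyl on an aromatic carbon gives a number 16.6 percentage points lower from compound 2 to compound 4 (beyond the scatter), and chloro in place of methoxy gives a number 20.3 percentage points lower from compound 1 to compound 4 (beyond the scatter), whereas the earlier swap of methoxy for tert-butyl stayed within the scatter. On the sulfur, 4-chlorophenyl in place of phenethyl gives a number 33.7 percentage points lower from compound 3 to compound 4 (beyond the scatter), the largest step in this set, so compound 3 with its phenethyl chain stands above all three compounds with a substituted phenyl group, and among those three the number depends on what the ring carries. Nothing shown here explains why chloro goes with the lower number.

As far as these compounds go, it remains open whether the low number belongs to chlorine itself or would also appear with another halogen such as fluorine or bromine, and how an amine or a carboxylic acid on the same ring would behave. From the compounds shown here alone, it is also open how a benzyl group or a longer chain on the sulfur would compare with phenethyl, and whether a chloro group on the ring of a phenethyl chain would lower the number as well.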